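The source may report more compounds than this note shows. Statements on the series, on what has been measured and on what is new or still open speak of the compounds shown alone.

Compound 1 (`O=C(Nc1ccccn1)c1cccc(Nc2ncc(F)c(Nc3ccc(F)cc3)n2)c1`) gives 13700 nM in a functional assay on KBVIN cells (Homo sapiens) for antiproliferative activity, read by sulforhodamine B assay, with a stated time of 3 days; a higher number here means a weaker inhibitor of growth, a lower number a stronger inhibitor of growth. Compound 2 (`O=C(Nc1nccs1)c1cccc(Nc2ncc(F)c(Nc3ccc(F)cc3)n2)c1`) gives > 10000 nM in this assay, which is a limit and not a number. Compound 3 (`O=C(Nc1ccc(C(F)(F)F)cc1)c1cccc(Nc2ncc(F)c(Nc3ccc(F)cc3)n2)c1`) differs from compound 2 by one change, (4-(trifluoromethyl)phenyl in place of 1,3-thiazol-2-yl on an amide-type nitrogen), with 4-(trifluoromethyl)phenyl in place of 1,3-thiazol-2-yl on an amide-type nitrogen. Among the measured compounds shown here, the only measured step that bears on it, a step that the limit leaves unreadable from compound 1 to compound 2, has no readable size, and the limit of > 10000 nM in this assay, at which 1 of the 2 values shown sits, shows how much of the evidence is a limit. For the measured compounds named here, with compound 1 at 13700 nM as the sole number, no clear gain is expected. The expected step, a step that the limit leaves unreadable from compound 2 to compound 3, is none beyond the scatter. For compound 3 the estimate is 11000 nM, with an expected range of 4000 nM to 25000 nM.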

Compound 3, concentration for 50% growth inhibition: > 10000 nM
Compound 3 gave a limit, no number; the forecaster's own chance of this, stated with the estimate: 55%; the middle value does not contradict the limit.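

Among the compounds shown here, compound 2 and compound 3 each stand only as a limit in this assay, and no step among compound 1, compound 2 and compound 3 can be read. The compounds shown leave open how far the group on the amide-type nitrogen alters growth inhibition.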